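The compounds below may be only part of what the source reports. "The series", "measured", "known", "first", "only" and "open" are said of these compounds alone.

Measured compounds:
compound 1 `COc1ccc(CNc2ncc(C(=O)O)c3nc(-c4ccco4)nn23)cc1OC` gives > 30000 nM
compound 2 `CCOC(=O)c1cnc(NC2CC2)n2nc(-c3ccco3)nc12` gives 2260 nM
compound 3 `CCOC(=O)c1cnc(N(C)C)n2nc(-c3ccco3)nc12` gives > 10000 nM

Of the three, only compound 2 returns a number in a functional assay on CHO cells for antagonist activity at adenosine receptor A2b (Homo sapiens) (a lower number here means a stronger inhibitor, a higher number a weaker inhibitor), namely 2260 nM. For compound 3 this assay reports only a limit, > 10000 nM. For compound 1 this assay also reports only a limit, > 30000 nM. Compound 1 therefore stands at a limit, with no number behind it, and it shares that standing with compound 3 (the limit of > 10000 nM in this assay, at which 1 of the 3 values shown sits, and (the limit of > 30000 nM in this assay, at which 1 of the 3 values shown sits)). Among the compounds with values here, the single measured step, an at least 4.4-fold higher number from compound 2 to compound 3 (0.64 log units; beyond the scatter), concerns the amine on the shared core and not the benzyl ring, so it does not bear on the change examined here. Within the data shown here, compound 1 differs from compounds 2 and 3 in more than one place, so no step is computed between them.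

Compound 4, `COc1ccc(CNc2ncc(C(=O)O)c3nc(-c4ccco4)nn23)cc1`, differs from compound 1 by hydrogen in place of methoxy on an aromatic carbon. Among the measured compounds shown here, no measured step touches this change. Because compound 1 gives only the limit > 30000 nM, the starting point is itself unknown beyond that limit. Compound 4 is expected to remain weak, at an estimated 30000 nM with a range from 6000 nM to 150000 nM. The expected step of a number no higher from compound 1 to compound 4 (the limit leaves the size open) is estimated to stay within the scatter.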

Compound 4, inhibition constant: > 30000 nM
Compound 4: only a limit was reported (the forecaster's own chance of this, stated with the estimate: 70%); the middle value sits exactly at the limit.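

In this assay compound 4 gives only a limit, > 30000 nM. Compound 1 likewise gives only a limit, > 30000 nM, and the step from compound 1 to compound 4 cannot be read. The compounds shown leave open whether hydrogen in place of methoxy changes the true inhibition constant.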